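Phenyl-to-methyl on the pyrazole nitrogen: carrying the step to compound 4

This account rests on a few compounds, and the source may have more. Where it says the series, first, only, none or still open, it means among the compounds named here.

Compound 1 `CCCN1CCC2(CC1)OC(OC)Cc1c2cnn1-c1ccccc1` is measured in an assay for displacement of a labelled ligand from Sigma non-opioid intracellular receptor 1 (Cavia porcellus), read by scintillation counting, with a stated time of 180 min (a higher number here means a weaker inhibitor, a lower number a stronger inhibitor), where compound 1 gives 33 nM. Compound 2 `CCCN1CCC2(CC1)OC(OC)Cc1c2cnn1C` differs by methyl in place of phenyl on an aromatic nitrogen; the step of an at least 30-fold higher number from compound 1 to compound 2 (1.48 log units; beyond the scatter) is large. For compound 2 the value > 1000 nM in this assay is a limit of the assay and not a number (the limit of > 1000 nM in this assay, at which 1 of the 3 values shown sits). Compound 3 `C1=Cc2c(cnn2-c2ccccc2)C2(CCN(Cc3ccccc3)CC2)O1` gives 1.48 nM in this assay, the lowest number of the two measured; the difference between the core of compound 3 and that of compound 1 is not broken down here. Compound 4 `Cn1ncc2c1C=COC21CCN(Cc2ccccc2)CC1` differs from compound 3 by methyl in place of phenyl on an aromatic nitrogen, the same change as seen from compound 1 to compound 2. Resting on an at least 30-fold higher number from compound 1 to compound 2 (1.48 log units; beyond the scatter), a loss of comparable size is expected, a 41-fold higher number from compound 3 to compound 4 (1.61 log units; beyond the scatter). For compound 4 the estimate in this assay is 60 nM, spanning 15 nM to 400 nM.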

Compound 4, inhibition constant: 12 nM
Beside the measured number, compound 4's estimate is 5.0-fold (0.70 log units) above it; measured number below the stated range.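

In this assay, methyl in place of phenyl on an aromatic nitrogen weakens binding on both cores, and on the core of compound 3 the result is an 8.1-fold higher number from compound 3 to compound 4 (0.91 log units; beyond the scatter). The direction of the change carries from one core to the other, but its size does not, and two cores give no rule for a third: the same change on two cores in this assay, an at least 30-fold higher number (1.48 log units; beyond the scatter) from compound 1 to compound 2 and an 8.1-fold higher number (0.91 log units; beyond the scatter) from compound 3 to compound 4, at least 3.7-fold (0.57 log units) apart, beyond the scatter of two such steps The value of compound 2, > 1000 nM, is a limit of the assay and not a number.

As far as these compounds go, it remains open whether the gap between the two steps goes with the propyl or benzyl group or with another part of the core. Also open, from the compounds shown here alone, is how cyclohexyl or a longer chain such as butyl would compare with phenyl and methyl in that place on either core.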